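The source may hold more compounds than are shown below. What is called first, only, known or untested is meant among the compounds shown, and "the series" means these compounds.

Of the compounds shown here, two have been measured in an ADME assay on HepG2 cells (Homo sapiens) for cytotoxicity, read by luminescence, CellTiter-Glo and ATP content, with a stated time of 72 h; a lower number here means that less compound is needed, a higher number that more compound is needed for the effect. Compound 1 `CCC(CC)c1ccc2c(NCCCNCc3cc(F)ccc3OC)ccnc2c1` gives 7860 nM in this assay. Compound 2 `CN(C)c1cccc(Oc2ccc3c(NCCCNCc4ccco4)ccnc3c2)c1` gives 16000 nM in this assay, the higher of the two numbers, and its distance from compound 1 lies beyond the usual scatter.

Compound 3 `COc1ccc(F)cc1CNCCCNc1ccnc2cc(Oc3cccc(N(C)C)c3)ccc12` has not yet been measured. It differs from compound 2 by one change: 5-fluoro-2-methoxyphenyl in place of furan-2-yl on a saturated chain carbon bound to an amine nitrogen. Compound 3 thus carries the same 5-fluoro-2-methoxybenzyl group as compound 1 while keeping the remainder of compound 2.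

Going by the values given here, no comparable step has been measured, so the size of the step is uncertain. A small move toward a lower number is expected for compound 3 in this assay because compound 1 with the same 5-fluoro-2-methoxybenzyl group gives 7860 nM. The expected step is a 1.5-fold lower number from compound 2 to compound 3 (0.16 log units; within the scatter). Compound 3 is estimated to give 11000 nM in this assay, with a range from 4500 nM to 27000 nM.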

Compound 3, half-maximal effective concentration: 3300 nM
Beside the measured number, compound 3's estimate is 3.3-fold (0.52 log units) above it; the measured number lies below the stated range.
By their numbers in this assay, from the lowest: compound 3; then compound 1; then compound 2.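

In this assay the group on a saturated chain carbon bound to an amine nitrogen proves to matter: 5-fluoro-2-methoxyphenyl in place of furan-2-yl gives a 4.8-fold lower number from compound 2 to compound 3 (0.69 log units; beyond the scatter) with the rest of the molecule unchanged. The aromatic carbon also proves to matter: 3-(dimethylamino)phenoxy in place of pentan-3-yl gives a 2.4-fold lower number from compound 1 to compound 3 (0.38 log units; beyond the scatter) with the 5-fluoro-2-methoxybenzyl group held constant. No measurement shown accounts for either step.

From the compounds shown here alone, it remains open whether the fluorine, the methoxy group or the benzene ring itself carries the change at the chain, a question that a plain benzyl group, or a benzyl group bearing only one of those two substituents, could address. Also open, going by these compounds, is whether furan-2-yl would give the same step with pentan-3-yl on the aromatic carbon.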